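Sulfone Ring in Place of Isopropyl: Expected Solubility

The source may report more compounds than this note shows. Statements on the series, on what has been measured and on what is new or still open speak of the compounds shown alone.

Three compounds have been measured in a physicochemical assay for solubility, measured as kinetic solubility; a higher number here means a more soluble compound, a lower number a less soluble compound:

Compound 1, `CCC/N=C1\S/C(=C\c2ccc(O)c(Cl)c2)C(=O)N1c1ccccc1C`: 79000 nM
Compound 2, `CCC/N=C1\S/C(=C\c2ccc(O)c(Cl)c2)C(=O)N1c1ccccc1OC`: 79000 nM
Compound 3, `CCC/N=C1\S/C(=C\c2ccc(O)c(Cl)c2)C(=O)N1C(C)C`: 20000 nM

Compound 3 stands lowest of the three: a 4.0-fold lower number from compound 1 to compound 3 (0.60 log units; beyond the scatter), and likewise a 4.0-fold lower number from compound 2 to compound 3 (0.60 log units; beyond the scatter), whereas no change at the digits printed from compound 1 to compound 2 (within the scatter). Within the data shown here, the only changes seen so far at the ring nitrogen swap an aromatic group for isopropyl, and both gave a modest drop.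

Compound 4, `CCC/N=C1\S/C(=C\c2ccc(O)c(Cl)c2)C(=O)N1C1CCS(=O)(=O)CC1`, differs from compound 3 in one place: 1,1-dioxothian-4-yl in place of isopropyl on an amide-type nitrogen in a ring. Among the measured compounds shown here, no measured step covers this exchange, so the two steps onto isopropyl serve only as a rough guide to how much this position can move the number. Since groups larger than isopropyl at this nitrogen gave higher numbers in compounds 1 and 2, a modest rise is expected for compound 4, a 2.0-fold higher number from compound 3 to compound 4 (0.30 log units; within the scatter), though the range is wide. Compound 4 is therefore estimated at 40000 nM, with a range from 12000 nM to 130000 nM.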

Compound 4, solubility: 75000 nM
The estimate for compound 4 lay 1.9-fold (0.27 log units) below the measured number; low and high end bracket the measured number.
By their numbers in this assay, from the lowest: compound 3; then compounds 4, 1 and 2 (each within the scatter of the next).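

In this assay, the amide-type nitrogen in the ring does not need an aromatic group to reach the higher numbers: the non-aromatic 1,1-dioxothian-4-yl ring gives a 3.8-fold higher number from compound 3 to compound 4 (0.57 log units; beyond the scatter). The same ring sits level with both aromatic groups, as shown by a 1.1-fold lower number from compound 2 to compound 4 (0.02 log units; within the scatter) and a 1.1-fold lower number from compound 1 to compound 4 (0.02 log units; within the scatter), so among these four compounds only isopropyl stands apart. No measurement shown here explains this result.

Still open, on these data alone, is whether the sulfone itself matters or whether any six-membered ring would do, a question that a plain cyclohexyl group, with only carbon in the ring, could help to settle. Also open, as far as these compounds go, is how an amine such as piperidin-4-yl, or a group carrying a carboxylic acid, would read at this nitrogen.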